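Swapping a Dimethoxyphenyl for a Methylthiophene

The source may hold more compounds than are shown below. What is called first, only, known or untested is meant among the compounds shown, and "the series" means these compounds.

Compound 1 `COc1ccc(CN(C(=O)Nc2ccc(Cl)cc2)n2cnnc2)cc1OC`; in a functional assay on MCF7 cells (Homo sapiens) for cytotoxicity, read by MTT assay, with a stated time of 48 h (on this read-out lower numbers stand for stronger inhibition and higher numbers for weaker inhibition), compound 1 gives > 50000 nM, which is a limit of the assay and not a number.
Compound 2 `COc1ccc(CN(C(=O)Nc2ccc(Cl)c(C(F)(F)F)c2)n2cnnc2)cc1OC`; in this assay compound 2 gives > 50000 nM, again a limit of the assay rather than a number.

Compound 1 and compound 2 share one core and differ in a single place, trifluoromethyl in place of hydrogen on an aromatic carbon. The step between them is a step that the two limits leave unreadable from compound 1 to compound 2, so its size cannot be told. Compound 2 therefore stands at the limit of > 50000 nM in this assay, at which 2 of the 2 values shown sit, without a number of its own in this assay.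

Compound 3 `Cc1ccsc1CN(C(=O)Nc1ccc(Cl)c(C(F)(F)F)c1)n1cnnc1` has not yet been measured. It differs from compound 2 by 3-methylthiophen-2-yl in place of 3,4-dimethoxyphenyl on a saturated chain carbon bound to an amide-type nitrogen. Among the measured compounds shown here, no measured step touches this position, and the single measured step has no readable size, so the only guide is that both measured compounds sit at the limit. In this assay compound 3 is expected to show a step that the limit leaves unreadable from compound 2 to compound 3 from compound 2, most likely once more as a limit. The estimate for compound 3 is 60000 nM, with a range from 15000 nM to 250000 nM.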

Compound 3, half-maximal inhibitory concentration: 30100 nM
The estimate for compound 3 lay 2.0-fold (0.30 log units) above the measured number; low and high end bracket the measured number.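

In this assay, among the compounds shown here, the saturated chain carbon bound to an amide-type nitrogen is the first place in this short series where a change gives a readable number: 3-methylthiophen-2-yl in place of 3,4-dimethoxyphenyl produces an at least 1.6-fold lower number from compound 2 to compound 3 (0.22 log units; that floor lies within the scatter). That step is only a floor, so the real gap could be larger, or it could be no more than ordinary scatter between repeated measurements. The earlier step, trifluoromethyl in place of hydrogen on an aromatic carbon, cannot be read, which leaves this position as the only one with any measured sign of a difference, and the series still sits mostly at the ceiling: the limit of > 50000 nM in this assay, at which 2 of the 3 values shown sit.

This single replacement alters the ring type, the ring size, the methyl group and the number of heavy atoms all at once, so the compounds shown cannot say which of these matters, or whether a real difference exists at all. A plain thiophen-2-yl without the methyl, or a chain ending in an amine at this place, would help to separate these possibilities.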